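The source may hold more compounds than are shown below. What is called first, only, known or untested is meant among the compounds shown, and "the series" means these compounds.

Compounds measured so far in a functional assay on DU-145 cells (Homo sapiens) for cytotoxicity, read by MTT assay (on this read-out higher numbers stand for weaker inhibition and lower numbers for stronger inhibition), are:

- compound 1 `CC(=O)OCCC(=O)O[C@H](CC=C(C)C)C1=CC(=O)c2c(O)ccc(O)c2C1=O` gives 15700 nM
- compound 2 `CC[C@](C)(O)CC(=O)O[C@H](CC=C(C)C)C1=CC(=O)c2c(O)ccc(O)c2C1=O` gives 20500 nM
- compound 3 `CCCCCCC(C)(O)CC(=O)O[C@H](CC=C(C)C)C1=CC(=O)c2c(O)ccc(O)c2C1=O` gives > 100000 nM (a limit, not a number)

Compound 3 therefore has no exact value. Compound 4 `CC(C)=CC[C@@H](OC(=O)C1CCOC1)C1=CC(=O)c2c(O)ccc(O)c2C1=O` carries oxolan-3-yl in place of 2-hydroxy-2-methyloctyl on a carbonyl carbon, a smaller group by that count. For the measured compounds named here, two measured steps bear on this change, both ending at compound 3 and both beyond the scatter: an at least 6.3-fold higher number from compound 1 to compound 3 (0.80 log units; beyond the scatter) and an at least 4.8-fold higher number from compound 2 to compound 3 (0.68 log units; beyond the scatter). Between the two compounds with smaller groups, a 1.3-fold higher number from compound 1 to compound 2 (0.12 log units; within the scatter) shows little sensitivity. A reversal towards stronger inhibition is therefore expected, at least as large as those steps. The estimated change is an at least 5.5-fold lower number from compound 3 to compound 4 (0.74 log units; beyond the scatter) in this assay on this reasoning. For compound 4 the expected value is 18000 nM (estimated range 7000 nM to 50000 nM).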

Compound 4, half-maximal inhibitory concentration: 47500 nM
Compound 4: middle estimate off by 2.6-fold (0.42 log units), on the low side; low and high end bracket the measured number.
By their numbers in this assay, from the lowest: compounds 1 and 2 (each within the scatter of the next); then compound 4. At a limit, above all of these: compound 3.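

On this carbonyl carbon, oxolan-3-yl in place of 2-hydroxy-2-methyloctyl gives stronger inhibition, with an at least 2.1-fold lower number from compound 3 to compound 4 (0.32 log units; beyond the scatter). Compound 3 has only a limit and not an exact number: the limit of > 100000 nM in this assay, at which 1 of the 4 values shown sits. A small group alone does not restore the earlier level, however, since the ring still gives weaker inhibition than the open chains, with a 2.3-fold higher number from compound 2 to compound 4 (0.36 log units; beyond the scatter) and a 3.0-fold higher number from compound 1 to compound 4 (0.48 log units; beyond the scatter).

The compounds shown leave open how an amine or a carboxylic acid on this carbonyl carbon would compare. They also leave open whether a cyclopentyl ring, which lacks the ring oxygen, would read like oxolan-3-yl.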